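The compounds below may be only part of what the source reports. "The series", "measured", "known", "first", "only" and "open" are said of these compounds alone.

Compound 1 `CCOC(=O)c1ccc(OC(=O)c2ccc3c(c2)C(C)(C)CCN3C)cc1` is the starting point of this account. In a functional assay on CV-1 cells for activation of retinoic acid receptor alpha (Homo sapiens) (a higher number here means a larger maximal response, a lower number a smaller maximal response), compound 1 gives 45%, the lowest of the two numbers measured here; its nearest neighbour is compound 2 `CCOC(=O)c1ccc(OC(=O)c2cc3c(cc2C)N(C)CCC3(C)C)cc1`, which in this assay gives 64%. For the measured compounds named here, the only measured step among the shared core's variants is a number 19 percentage points higher from compound 1 to compound 2 (beyond the scatter), a change on an aromatic carbon.

Compound 3 `CCOC(=O)c1ccc(OC(=O)c2ccc3c(c2)C(C)(C)CCN3C(C)C)cc1` differs from compound 1 in another place: isopropyl in place of methyl on a nitrogen on an aromatic ring in a ring. Going by the values given here, no measured step touches this nitrogen, so the change on the aromatic carbon from compound 1 to compound 2 does not bear directly on it, and the sole guide is the value of compound 1 itself. The expected step is therefore small, a number 5 percentage points higher from compound 1 to compound 3 (within the scatter), with no direction supported beyond the scatter. Compound 3 is estimated to give 50% in this assay, within a range from 28% to 75%.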

Compound 3, largest response reached (reported as efficacy), in percent of the reference or control that the assay uses: 59%
Beside the measured number, compound 3's estimate is 9 percentage points below it; the range from low to high includes it.
By their numbers in this assay, from the lowest: compound 1; then compounds 3 and 2 (each within the scatter of the next).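

In this assay, the substituent on this nitrogen proves to matter: with isopropyl in place of methyl there is a number 14 percentage points higher from compound 1 to compound 3 (beyond the scatter). For the compounds shown here, this is the first measured change at the nitrogen, and it shows that the maximal response of the core of compound 1 can shift at a second place, not only at the aromatic carbon. Nothing shown here explains why the exchange of methyl for isopropyl raises the number.

The compounds shown leave open how the response would run with a longer chain such as n-butyl, with a benzyl group, or with a hydrogen on this nitrogen. They also leave open whether isopropyl on the nitrogen and methyl on the aromatic carbon would add up when carried together on the shared core.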